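A few compounds are considered here, and "the series" means these few. Any claim that something is new, unique, unknown or untested is made for them only; others in the source may bear on it.

Compound 1: `C[C@H](c1ccc(F)cc1)N(Cc1cccc(C(=O)O)c1)C(=O)c1cc2ccccc2s1`; in an assay on CHO T-rex cells for antagonist activity at transient receptor potential cation channel subfamily M member 8 (Homo sapiens), read by calcium flux, with a stated time of 20 min (a higher number here means a weaker inhibitor, a lower number a stronger inhibitor), compound 1 gives 145 nM.
Compound 2: `O=C(O)c1cccc(CN(Cc2ccc(F)cc2)C(=O)c2cnc3ccccc3c2)c1`; in this assay compound 2 reaches only the assay limit > 9350 nM.
Compound 3: `O=C(O)c1cccc(CN(C(=O)c2cnc3ccccc3c2)[C@H](CO)c2ccccc2)c1`; in this assay compound 3 reaches only the assay limit > 6860 nM.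

Compound 3 therefore stands at a limit, not a number, and so does compound 2, as the limit of > 6860 nM in this assay, at which 1 of the 3 values shown sits, and the limit of > 9350 nM in this assay, at which 1 of the 3 values shown sits, show. The step that the two limits leave unreadable from compound 2 to compound 3 is unreadable. Compound 4, `COc1ccc(C(C)N(Cc2cccc(C(=O)O)c2)C(=O)c2cnc3ccccc3c2)cc1`, differs from compound 3 by 1-(4-methoxyphenyl)ethyl in place of 2-hydroxy-1-phenylethyl on an amide-type nitrogen. For the measured compounds named here, no measured step bears directly on this change: the only one on the shared core of compounds 2 and 3 is unreadable, and compound 1, which carries a related branched group on a different core, gives a numerical value. For compound 4 an inhibitory concentration of 3000 nM is expected, within 500 nM to 15000 nM. The expected step of an at least 2.2-fold lower number from compound 3 to compound 4 (0.35 log units; beyond the scatter) cannot be read against the limit.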

Compound 4, half-maximal inhibitory concentration: 6100 nM
For compound 4 the middle estimate is 2.0-fold (0.31 log units) below the measured one; measured number inside the range.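

Compound 4 gives the shared core its first numerical value, 6100 nM in this assay, with 1-(4-methoxyphenyl)ethyl on the amide-type nitrogen. The change reads as an at least 1.1-fold lower number from compound 3 to compound 4 (0.05 log units; that floor lies within the scatter) and an at least 1.5-fold lower number from compound 2 to compound 4 (0.18 log units; that floor lies within the scatter); both steps start from limits, so they are only floors and neither establishes a change. Compound 3 stands at a limit, not a number: the limit of > 6860 nM in this assay, at which 1 of the 4 values shown sits.

Compound 1 differs from compound 4 in more than one place, so the two cannot be compared directly. As far as these compounds go, what an amine or a nitrile in place of the methoxy group on the 1-(4-methoxyphenyl)ethyl group would give remains open.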